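Compound 4: Methyl in Place of Phenyl on the Core

The compounds below may be only part of what the source reports. "The series", "measured", "known", "first", "only" and "open" are said of these compounds alone.

Three compounds sharing one core were measured in an assay on isolated protein for binding affinity to Alpha-1B adrenergic receptor (Homo sapiens), read by radioligand binding; a lower number here means a stronger inhibitor, a higher number a weaker inhibitor. Compound 1 `COc1ccccc1N1CCN(CCNc2cc(-c3ccccc3)nn(C)c2=O)CC1` gives 2.01 nM in this assay. Compound 2 `CC(=O)c1c(-c2ccccc2)nn(C)c(=O)c1NCCN1CCN(c2ccccc2F)CC1` gives 3.77 nM in this assay, a number within the scatter of compound 1. Going by the values given here, compound 3 `COc1ccccc1N1CCN(CCNc2c(C(=O)C(C)C)c(-c3ccccc3)nn(C)c2=O)CC1` gives 0.64 nM in this assay; the step of a 3.1-fold lower number from compound 1 to compound 3 (0.50 log units; beyond the scatter) is the only change among the measured compounds that lies beyond the scatter. Compound 1 therefore stands second highest of the three numbers, with compound 2 nearest and compound 3 furthest.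

Compound 4 `COc1ccccc1N1CCN(CCNc2cc(C)nn(C)c2=O)CC1` differs from compound 1 by methyl in place of phenyl on an aromatic carbon. Among the compounds with values here, no measured step bears directly on this change: the step from compound 1 to compound 3 concerns an isopropylcarbonyl at another aromatic carbon, and compound 2 differs from compound 1 in more than one place. The expectation for compound 4 therefore rests on the change itself, in which a six-membered aromatic ring of six carbon atoms gives way to a single carbon, and a higher number, that is a weaker inhibitor, is expected in this assay. Compound 4 is expected to give about 12 nM, within a range from 2.5 nM to 60 nM. The expected step is a 6.0-fold higher number from compound 1 to compound 4 (0.78 log units; beyond the scatter), modest in size and uncertain in the absence of a comparable measured step.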

Compound 4, inhibition constant: 33.1 nM
For compound 4 the middle estimate is 2.8-fold (0.44 log units) below the measured one; the measured number falls inside the stated range.
By their numbers in this assay, from the lowest: compound 3; then compounds 1 and 2 (each within the scatter of the next); then compound 4.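

In this assay, going by these compounds alone, methyl in place of phenyl on the aromatic carbon next to the ring nitrogen gives a 16-fold higher number from compound 1 to compound 4 (1.22 log units; beyond the scatter), the first look at what this position tolerates. The change is larger in size than the other single-place change on this core, a 3.1-fold lower number from compound 1 to compound 3 (0.50 log units; beyond the scatter), and it runs the opposite way, so the number responds strongly to the group at this position. Neither phenyl nor methyl carries hydrogen-bond donors, hydrogen-bond acceptors or a net charge, so the two groups differ here in heavy atoms and in the ring, and the step by itself cannot separate these two differences. Nothing among the data shown accounts for the step.

The compounds shown leave open whether an aromatic ring is needed at this position or whether a cyclohexyl or a longer chain such as butyl would serve as well, and how a phenyl bearing a methoxy group or a pyridyl ring would compare. They also leave open whether the isopropylcarbonyl of compound 3 would lower the number to a similar degree on the core of compound 4.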